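A few compounds are considered here, and "the series" means these few. Any claim that something is new, unique, unknown or untested is made for them only; others in the source may bear on it.

Compound 1 `COc1ccc(Cc2cnc(CCc3ccc(-c4ccccc4C(=O)O)cc3)[nH]2)cc1` is a small molecule tested in an in vitro functional assay on cells for agonist activity at Bombesin receptor subtype-3 (Homo sapiens), read by luminescence and calcium flux (on this read-out lower numbers stand for an effect already at smaller amounts and higher numbers for an effect only at larger amounts of compound), where compound 1 gives 5360 nM. A close relative, compound 2 `N#Cc1ccccc1Cc1cnc(CCc2ccc(-c3ccccc3C(=O)O)cc2)[nH]1`, was measured in the same way, and compound 2 gives 5480 nM, so the two numbers lie within the usual scatter of each other and neither stands apart. For the measured compounds named here, the one measured step, a 1.0-fold higher number from compound 1 to compound 2 (0.01 log units; within the scatter), shows that swapping the group on the saturated chain carbon bound to an aromatic carbon left the read-out essentially unchanged. Compound 3 `COc1ccccc1Cc1cnc(CCc2ccc(-c3ccccc3C(=O)O)cc2)[nH]1` has not yet been measured. It differs from compound 1 by 2-methoxyphenyl in place of 4-methoxyphenyl on a saturated chain carbon bound to an aromatic carbon. Going by the values given here, no measured pair shows this exact rearrangement, and the only step that touches this part of the molecule stayed within the scatter, so the step of a 1.1-fold lower number from compound 1 to compound 3 (0.03 log units; within the scatter) is expected to be small or absent. Compound 3 is therefore estimated to give 5000 nM, with a likely range from 2000 nM to 14000 nM.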

Compound 3, half-maximal effective concentration: 1720 nM
Compound 3: the middle estimate sits 2.9-fold (0.46 log units) above what was measured; measured number outside the range, below it.
By their numbers in this assay, from the lowest: compound 3; then compounds 1 and 2 (each within the scatter of the next).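

In this assay, the position on the saturated chain carbon bound to an aromatic carbon turns out not to be indifferent, although the first pair suggested it was. Moving from 4-methoxyphenyl to 2-methoxyphenyl changes the result (a 3.1-fold lower number from compound 1 to compound 3 (0.49 log units; beyond the scatter)), so the arrangement of the same atoms matters here. Methoxy in place of cyano on an aromatic carbon also changes it (a 3.2-fold lower number from compound 2 to compound 3 (0.50 log units; beyond the scatter)), so among these three compounds only 2-methoxyphenyl, which combines the methoxy group with the arrangement of compound 2, stands apart from the others.

From the compounds shown here alone, it remains open whether an ethoxy group or a chlorine atom in place of the methoxy of compound 3 would lower the number further. No measurement shown here explains why either step occurs.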